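The source may report more compounds than this note shows. Statements on the series, on what has been measured and on what is new or still open speak of the compounds shown alone.

In a functional assay with Oryctolagus cuniculus as the target (on this read-out lower numbers stand for stronger inhibition and higher numbers for weaker inhibition), compound 1 (`COc1ccc(-c2nc(/N=C(\N)NC(C)C)sc2-c2ccc(OC)cc2)cc1`) gives > 100 nM, which is a limit of the assay and not a number. Compound 2 (`COc1ccc(-c2nc(C(N)=O)sc2-c2ccc(OC)cc2)cc1`) gives > 1000 nM, and this too is only a limit, so its place in the series cannot be fixed any more closely. Neither compound has an exact value to serve as a reference.

Compound 3 (`CCOC(=O)/C(C#N)=C/c1nc(-c2ccc(OC)cc2)c(-c2ccc(OC)cc2)s1`) keeps the two 4-methoxyphenyl groups of compound 2 but carries 2-cyano-2-(ethoxycarbonyl)ethenyl in place of carbamoyl on an aromatic carbon.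

Within the data shown here, only one measured step bears on this change, a replacement on the same aromatic carbon: a step that the two limits leave unreadable from compound 1 to compound 2. It offers no size to carry over, and it points in no direction. In this assay, on these data alone, therefore, no step beyond the scatter is expected from the limit of compound 2, and the true size remains open. The estimated change is a step that the limit leaves unreadable from compound 2 to compound 3. For compound 3 the expected value is 2000 nM, with an estimated range from 300 nM to 10000 nM.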

Compound 3, half-maximal inhibitory concentration: < 10 nM
Compound 3: no number, only a limit; the forecaster's own chance of this, stated with the estimate: 60%; middle value at least 200-fold (2.30 log units) from the limit.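

In this assay compound 3 gives < 10 nM, which is a limit of the assay and not a number. With the two 4-methoxyphenyl groups unchanged, the aromatic carbon next to the ring nitrogen and next to the ring sulfur now yields a readable change: 2-cyano-2-(ethoxycarbonyl)ethenyl in place of carbamoyl gives an at least 100-fold lower number from compound 2 to compound 3 (2.00 log units; beyond the scatter). The same group in place of the substituent of compound 1 on this carbon gives an at least 10-fold lower number from compound 1 to compound 3 (1.00 log units; beyond the scatter), so the read-out at this position clearly depends on what the carbon carries, and compound 3 stands apart from both earlier compounds.

On these data alone, the step between compound 1 and compound 2 cannot be read, and both readable steps are bounded by limits, so their full sizes remain open. The compounds shown also do not separate the parts of the new group, so it cannot be told whether the nitrile alone, the ethoxycarbonyl alone, a carboxylic acid in place of the ester or a saturated chain in place of the ethenyl link would give a similar result.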